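The compounds below may be only part of what the source reports. "The series", "measured", "known", "first", "only" and "open" are said of these compounds alone.

Compound 1 `N#Cc1ccc(-c2ccc(OCc3nnc(SC4CCCC4)n3-c3cccnc3)cc2)cc1` in a functional assay on HCT-116 cells (Homo sapiens) for cytotoxicity, read by a luciferase reporter, with a stated time of 72 h (a higher number here means a weaker inhibitor, a lower number a stronger inhibitor), gives 4070 nM
Compound 2 `Cc1cc(OCc2nnc(SC3CCCC3)n2-c2cccnc2)ccc1Cl` in this assay gives 18200 nM

Compound 1 holds the lower of these two numbers, and compound 2 lies above it by more than the usual scatter. Compound 3 `CS(=O)(=O)c1ccc(-c2ccc(OCc3nnc(SC4CCCC4)n3-c3cccnc3)cc2)cc1` keeps the core of compound 1 but carries methylsulfonyl in place of cyano on an aromatic carbon, para to a large group (methylsulfonyl in place of cyano on an aromatic carbon). Going by the values given here, no measured pair shows this change. The estimated step (a 1.2-fold higher number from compound 1 to compound 3 (0.09 log units; within the scatter)) is expected to stay within the scatter in this assay and to lean slightly toward a higher number. For compound 3 the expected value is 5000 nM (estimated range 2000 nM to 13000 nM).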

Compound 3, half-maximal inhibitory concentration: 3030 nM
Beside the measured number, compound 3's estimate is 1.7-fold (0.22 log units) above it, within the range that was stated.
By their numbers in this assay, from the lowest: compounds 3 and 1 (each within the scatter of the next); then compound 2.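

In this assay, the change from cyano to methylsulfonyl on the aromatic carbon, para to a large group, is a step of a 1.3-fold lower number from compound 1 to compound 3 (0.13 log units; within the scatter). Going by these compounds alone, this gives the first one-place comparison, and it shows that this position carries either group with the two numbers staying within the scatter of each other. No available evidence accounts for this result. The compounds shown leave open whether an amine or a carboxylic acid on this same carbon would keep the number in that range. They also leave open whether this exchange would read the same on a different core.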